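A few compounds are considered here, and "the series" means these few. Any claim that something is new, unique, unknown or untested is made for them only; others in the source may bear on it.

Compound 1 `COc1ccc(/C=C/C(=O)Nc2cc(C(=O)c3cc(OC)c(OC)c(OC)c3)cc(OC)c2OC)cc1`: 6300 nM
Compound 2 `COc1cccc(/C=C/C(=O)Nc2cc(C(=O)c3cc(OC)c(OC)c(OC)c3)cc(OC)c2OC)c1`: 13300 nM
Compound 3 `COc1cc(C(=O)c2cc(OC)c(OC)c(OC)c2)cc(NC(=O)/C=C/c2ccc(F)cc2)c1OC`: 4100 nM

In a functional assay on PC-3 cells (Homo sapiens) for cytotoxicity, read by MTT assay, with a stated time of 72 h (on this read-out higher numbers stand for weaker inhibition and lower numbers for stronger inhibition), compound 3 has the lowest of the three numbers, yet its distance to compound 1 is within the scatter: a 1.5-fold lower number from compound 1 to compound 3 (0.19 log units; within the scatter). For the measured compounds named here, only the step from compound 2 stands beyond it: a 3.2-fold lower number from compound 2 to compound 3 (0.51 log units; beyond the scatter). Compound 4 `COc1cc(C(=O)c2cc(OC)c(OC)c(OC)c2)cc(NC(=O)/C=C/c2ccc(C(F)(F)F)cc2)c1OC` differs from compound 3 by trifluoromethyl in place of fluoro on an aromatic carbon. Going by the values given here, no measured step swaps exactly these two groups. What the shown steps do tell is that changes on this outer ring moved this assay only modestly, as in a 2.1-fold higher number from compound 1 to compound 2 (0.32 log units; beyond the scatter). A step of similar size, or none beyond the scatter, is therefore expected for a 1.2-fold higher number from compound 3 to compound 4 (0.09 log units; within the scatter). Compound 4 is estimated at 5000 nM, in the range 2000 nM to 15000 nM.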

Compound 4, half-maximal inhibitory concentration: 4200 nM
Compound 4: middle estimate off by 1.2-fold (0.08 log units), on the high side; measured number inside the range.
By their numbers in this assay, from the lowest: compounds 3, 4 and 1 (each within the scatter of the next); then compound 2.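

In this assay, trifluoromethyl in place of fluoro at this spot on the outer ring changes nothing that can be told apart: a 1.0-fold higher number from compound 3 to compound 4 (0.01 log units; within the scatter) stays within the scatter. Compound 4 also relates to the other two as compound 3 does, with a 3.2-fold lower number from compound 2 to compound 4 (0.50 log units; beyond the scatter) beyond the scatter and a 1.5-fold lower number from compound 1 to compound 4 (0.18 log units; within the scatter) within it. Nothing measured here gives a reason for these numbers.

Still open, on these data alone, is whether an amine or a carboxylic acid on this aromatic carbon would leave the number equally unmoved. Also open, as far as these compounds go, is how trifluoromethyl would fare where compound 2 carries its methoxy.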